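Swapping a Chloro-Fluoro Aryl Group for Methoxy

This account rests on a few compounds, and the source may have more. Where it says the series, first, only, none or still open, it means among the compounds named here.

In a functional assay on the whole organism (strain Wistar) with Rattus norvegicus as the target, with a stated time of 5 min (on this read-out higher numbers stand for an effect only at larger amounts of compound and lower numbers for an effect already at smaller amounts), compound 1 `CCC1(CCCCN2CCN(c3ccc(F)cc3)CC2)C(=O)Nc2ccccc21` gives 10 mg/kg. Compound 2 `CCC1(CCCCN2CCN(c3ccc(F)c(Cl)c3)CC2)C(=O)Nc2ccccc21` is reported in this assay only as a limit, > 20 mg/kg (the limit of > 20 mg/kg in this assay, at which 1 of the 2 values shown sits). Compound 3 `CCC1(CCCCN2CCN(c3ccc(OC)cc3)CC2)C(=O)Nc2ccccc21` differs from compound 2 by 4-methoxyphenyl in place of 3-chloro-4-fluorophenyl on an amine nitrogen in a ring. Within the data shown here, only one measured step bears on this, an at least 2.0-fold higher number from compound 1 to compound 2 (0.30 log units; that floor lies within the scatter), and compound 3 undoes that chloro while also exchanging the fluorine for methoxy, a change with no measured counterpart. Because compound 1 gives 10 mg/kg, compound 3 is estimated at 10 mg/kg, within 3 mg/kg to 40 mg/kg. That estimate means an expected step of an at least 2.0-fold lower number from compound 2 to compound 3 (0.30 log units; that floor lies within the scatter).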

Compound 3, minimum effective dose: > 20 mg/kg
Compound 3: only a limit was reported; the forecaster's own chance of this, stated with the estimate: 35%; middle value at least 2.0-fold (0.30 log units) away from the limit.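

Exchanging the fluoro of compound 1 for methoxy gives an at least 2.0-fold higher number from compound 1 to compound 3 (0.30 log units; that floor lies within the scatter), so a change at this spot on the aryl group can shift the read-out without any added chloro. Compound 3 is reported only as a limit, as compound 2 is, so the step between them cannot be read: the limit of > 20 mg/kg in this assay, at which 2 of the 3 values shown sit.

Going by these compounds, how far compound 2 and compound 3 lie past that limit stays open, and so does whether they differ at all. Also open, on these data alone, is how a hydroxy or methyl group in place of the fluoro of compound 1 would read.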